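Swapping an Alkyl for a Phenyl on a Sulfonamide Nitrogen

A few compounds are considered here, and "the series" means these few. Any claim that something is new, unique, unknown or untested is made for them only; others in the source may bear on it.

Three close analogues sharing one core have been measured in a functional assay on A549 cells (Homo sapiens) for antiproliferative activity, read by CCK-8 assay, with a stated time of 72 h; on this read-out higher numbers stand for weaker inhibition of growth and lower numbers for stronger inhibition of growth. Compound 1 `CC[C@@H]1C(=O)N(C)c2cnc(Nc3ccc(S(=O)(=O)NC4CCCC4)cc3)nc2N1C1CCCC1` gives 1150 nM; compound 2 `CCCCNS(=O)(=O)c1ccc(Nc2ncc3c(n2)N(C2CCCC2)[C@H](CC)C(=O)N3C)cc1` gives 477 nM; compound 3 `CC[C@@H]1C(=O)N(C)c2cnc(Nc3ccc(S(=O)(=O)NCC(C)C)cc3)nc2N1C1CCCC1` gives 750 nM, the second highest of the three numbers, separated from compound 1 by a 1.5-fold lower number from compound 1 to compound 3 (0.19 log units; within the scatter) and from compound 2 by a 1.6-fold higher number from compound 2 to compound 3 (0.20 log units; within the scatter). Among the compounds with values here, the only step beyond the scatter is a 2.4-fold lower number from compound 1 to compound 2 (0.38 log units; beyond the scatter).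

Compound 4 `CC[C@@H]1C(=O)N(C)c2cnc(Nc3ccc(S(=O)(=O)Nc4ccccc4)cc3)nc2N1C1CCCC1` differs from compound 3 in one place: phenyl in place of isobutyl on a sulfonamide nitrogen. All three measured steps concern changes on the same sulfonamide nitrogen or the chain attached to it, and two of them fall within the scatter, while the third is modest. None involves an aromatic group entering at this position, so the measured steps offer only an indirect guide, suggesting that substitution here moves the number little.

Compound 4 is therefore expected to give about 800 nM in this assay, with a plausible range from 300 nM to 2500 nM. The expected step is a 1.1-fold higher number from compound 3 to compound 4 (0.03 log units; within the scatter), which would stay within the scatter.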

Compound 4, concentration for 50% growth inhibition: 4150 nM
Beside the measured number, compound 4's estimate is 5.2-fold (0.71 log units) below it; the measured number lies above the stated range.
By their numbers in this assay, from the lowest: compounds 2, 3 and 1 (each within the scatter of the next, the first and the last beyond it); then compound 4.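

On the sulfonamide nitrogen in this assay, the aromatic group parts from the alkyl groups: phenyl in place of isobutyl gives a 5.5-fold higher number from compound 3 to compound 4 (0.74 log units; beyond the scatter) and points towards weaker inhibition of growth. The same holds against the other two alkyl groups, with an 8.7-fold higher number from compound 2 to compound 4 (0.94 log units; beyond the scatter) for phenyl in place of butyl and a 3.6-fold higher number from compound 1 to compound 4 (0.56 log units; beyond the scatter) for phenyl in place of cyclopentyl, so a ring as such does not set compound 4 apart, since cyclopentyl is also a ring. Compound 4 thus shows the weakest inhibition of growth of the four, and this position proves more sensitive to an aromatic ring than the alkyl groups alone suggested.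

Nothing available explains this step. From the compounds shown here alone, it remains open whether a benzyl, a cyclohexyl or a pyridyl group on the sulfonamide nitrogen would read like phenyl or like the alkyl groups.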